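The compounds below may be only part of what the source reports. "The series", "measured", "known", "first", "only" and "open" are said of these compounds alone.

Compound 1, `CCOC(=O)/C=C/C(=O)N(CC(N)=O)NC(=O)[C@@H]1CCCN1C(=O)C(C)(C)NC(C)=O`, is a peptide-like inhibitor. In an assay on isolated protein for inhibition of legumain (Mus musculus), read by fluorescence, with stated times of 30 s and 2.5 h (a lower number here means a stronger inhibitor, a higher number a weaker inhibitor), compound 1 gives 198 nM. Going by the values given here, that is the higher of the two numbers measured so far: compound 2, `CCOC(=O)C1OC1C(=O)N(CC(N)=O)NC(=O)[C@@H]1CCCN1C(=O)C1(NC(C)=O)CC1`, which differs from it at several spots, gives 4.4 nM, a much lower number and therefore a far stronger inhibitor. Compound 3, `C/C=C(\NC(C)=O)C(=O)N1CCC[C@H]1C(=O)NN(CC(N)=O)C(=O)/C=C/C(=O)OCC`, has not yet been measured. It differs from compound 1 at a single spot, on a carbonyl carbon whose other neighbour is an amide-type nitrogen in a ring: a group of 7 heavy atoms (5 carbon, 1 nitrogen, 1 oxygen; no ring) in place of a group of 7 heavy atoms (5 carbon, 1 nitrogen, 1 oxygen; no ring), on a carbonyl carbon. Among the compounds with values here, no measured pair shows the effect of this exchange, so nothing here says how this assay responds to it. The outgoing and incoming groups match closely in what is counted for them, and only a small step from compound 1 to compound 3 is expected, a 1.1-fold lower number from compound 1 to compound 3 (0.04 log units; within the scatter), lying within or near the usual scatter. Compound 3 is accordingly expected to give about 180 nM, with a plausible range from 60 nM to 600 nM.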

Compound 3, half-maximal inhibitory concentration: 141 nM
Beside the measured number, compound 3's estimate is 1.3-fold (0.11 log units) above it, and the stated range covers the measured number.
By their numbers in this assay, from the lowest: compound 2; then compounds 3 and 1 (each within the scatter of the next).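

In this assay, putting the group of compound 3, with one more double bond outside aromatic rings, in place of 1-acetamido-1-methylethyl on this carbonyl carbon gives a 1.4-fold lower number from compound 1 to compound 3 (0.15 log units; within the scatter). Going by these compounds alone, this is the first direct reading at this position, and it shows that this assay does not separate these two groups of equal heavy-atom count. No measurement shown here explains that outcome.

As far as these compounds go, whether an amine, a carboxylic acid or a longer chain at the same place would also leave the number within the scatter remains open. Compound 2, at 4.4 nM, differs from compound 1 at several spots, so the compounds shown do not tell which of its changes accounts for its number.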